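The compounds below may be only part of what the source reports. "The series", "measured", "known", "first", "only" and "open" are said of these compounds alone.

Working notes on the series. All four compounds share one core. Compound 1 `Cc1ccc(/C=N/NC(=O)COc2cccc3ccccc23)cc1` gives 80.1 ug/mL in an ADME assay on HEL cells (Homo sapiens) for cytotoxicity (a higher number here means that more compound is tolerated, a lower number that less compound is tolerated), and compound 2 `O=C(COc1cccc2ccccc12)N/N=C/c1cccc(O)c1` gives 62.7 ug/mL in this assay; a 1.3-fold lower number from compound 1 to compound 2 (0.11 log units; within the scatter). Compound 3 `C/C(=N\NC(=O)COc1cccc2ccccc12)c1ccc(O)cc1` gives 11.1 ug/mL in this assay, the lowest of the three numbers and beyond the scatter from both compound 2 and compound 1. Compound 4 `C/C(=N\NC(=O)COc1cccc2ccccc12)c1ccc(Br)cc1` differs from compound 3 by bromo in place of hydroxy on an aromatic carbon. Among the measured compounds shown here, no measured step exchanges a hydroxy for a bromo. The single-place step measured, a 1.3-fold lower number from compound 1 to compound 2 (0.11 log units; within the scatter), concerns a different change and lies within the scatter, and compounds 2 and 3, whose numbers differ beyond the scatter, differ in more than one place. The expected step is therefore modest, a 1.6-fold higher number from compound 3 to compound 4 (0.21 log units; within the scatter), toward a higher number. Compound 4 is expected at 18 ug/mL, in the range 7 ug/mL to 45 ug/mL.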

Compound 4, half-maximal cytotoxic concentration: 15.3 ug/mL
Compound 4: the middle estimate sits 1.2-fold (0.07 log units) above what was measured; low and high end bracket the measured number.
By their numbers in this assay, from the lowest: compounds 3 and 4 (each within the scatter of the next); then compounds 2 and 1 (each within the scatter of the next).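

Among the compounds shown here, the exchange of 4-hydroxyphenyl for 4-bromophenyl gives a 1.4-fold higher number from compound 3 to compound 4 (0.14 log units; within the scatter) in this assay and is the first measured step at this position, on an aromatic carbon para to a large group. Here, a hydroxy carrying a hydrogen-bond donor and acceptor and a bromo carrying neither cannot be told apart in this read-out.

Going by these compounds, whether an amine, a carboxylic acid or a longer chain at the same position would stay within the scatter remains open. No supporting data bear on this result.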